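A Further Methoxy on Compound 3

This account rests on a few compounds, and the source may have more. Where it says the series, first, only, none or still open, it means among the compounds named here.

In an ADME assay on K562 cells (Homo sapiens) for cytotoxicity, with a stated time of 72 h (a lower number here means a stronger inhibitor, a higher number a weaker inhibitor), compound 1 (`COc1ccccc1CNc1ncnc2c1ncn2C1CCCCO1`) gives 97000 nM. Compound 2 (`Oc1ccccc1CNc1ncnc2c1ncn2C1CCCO1`) is reported only as a limit, > 100000 nM. Compound 3 (`COc1ccccc1CNc1ncnc2c1ncn2C1CCCO1`) is also reported only as a limit, > 100000 nM. Going by the values given here, the numbers so far are therefore dominated by the limit of > 100000 nM in this assay, at which 2 of the 3 values shown sit, and compound 3 has no exact value from which to measure a change.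

Compound 4 (`COc1ccc(CNc2ncnc3c2ncn3C2CCCO2)c(OC)c1`) differs from compound 3 by methoxy in place of hydrogen on an aromatic carbon, meta to a methoxy group and para to a large group: methoxy in place of hydrogen on an aromatic carbon. Among the compounds with values here, no measured step covers this exact change. The closest in kind, methyl in place of hydrogen on an oxygen on an aromatic ring, is a step that the two limits leave unreadable from compound 2 to compound 3. The other, oxolan-2-yl in place of oxan-2-yl on an aromatic nitrogen, is an at least 1.0-fold higher number from compound 1 to compound 3 (0.01 log units; that floor lies within the scatter). Neither shows a readable change beyond the scatter, so no step beyond the scatter is expected in this assay, and no direction is favoured. The expected step is a number no higher from compound 3 to compound 4 (the limit leaves the size open). A report of only a limit is the more likely outcome for compound 4. Compound 4 is estimated at 100000 nM, with an expected range from 45000 nM to 200000 nM.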

Compound 4, half-maximal inhibitory concentration: > 100000 nM
Compound 4 gave a limit, no number; the forecaster's own chance of this, stated with the estimate: 70%; the middle value sits exactly at the limit.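

In this assay compound 4 gives > 100000 nM, which is a limit and not a number. Going by these compounds alone, compound 3 also stands only as a limit, so no step between compound 3 and compound 4 can be read. The compounds shown leave open whether methoxy in place of hydrogen changes the read-out at all, because most values sit at one limit: the limit of > 100000 nM in this assay, at which 3 of the 4 values shown sit.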